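From Methoxy to Phenyl: Expected Shift in Antiproliferative Potency

This account rests on a few compounds, and the source may have more. Where it says the series, first, only, none or still open, it means among the compounds named here.

Compound 3 `COc1ccc(-c2cc(N)c(C(=O)c3cc(OC)c(OC)c(OC)c3)s2)cc1` stands second highest of the three numbers in a functional assay on CCRF-CEM cells (Homo sapiens) for antiproliferative activity (on this read-out higher numbers stand for weaker inhibition and lower numbers for stronger inhibition), giving 19 nM. Compound 2 `COc1cc(C(=O)c2sc(-c3ccccc3)cc2N)cc(OC)c1OC` gives 4.5 nM, and compound 1 `COc1cc(C(=O)c2sc(-c3ccc(C(F)(F)F)cc3)cc2N)cc(OC)c1OC` gives 270 nM. Compound 4 `COc1cc(C(=O)c2sc(-c3ccc(-c4ccccc4)cc3)cc2N)cc(OC)c1OC` differs from compound 3 by a single change: phenyl in place of methoxy on an aromatic carbon. For the measured compounds named here, two measured steps bear on this. Putting methoxy in place of hydrogen gave a 4.2-fold higher number from compound 2 to compound 3 (0.63 log units; beyond the scatter), and the trifluoromethyl compound showed a 14-fold lower number from compound 1 to compound 3 (1.15 log units; beyond the scatter), while a 60-fold lower number from compound 1 to compound 2 (1.78 log units; beyond the scatter) confirms that hydrogen gave the lowest number of the three. Both groups placed on this aromatic carbon raised the number relative to hydrogen, so a phenyl there is expected to raise it further. Compound 4 is therefore estimated at 150 nM, within 30 nM to 700 nM, an expected 7.9-fold higher number from compound 3 to compound 4 (0.90 log units; beyond the scatter).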

Compound 4, half-maximal inhibitory concentration: > 10000 nM
Compound 4 ended at the assay's limit; the forecaster's own chance of this, stated with the estimate: 5%; at least 66-fold (1.82 log units) between middle value and limit.
By their numbers in this assay, from the lowest: compound 2; then compound 3; then compound 1. At a limit, above all of these: compound 4.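

Compound 4 stands at a limit of the assay, not at a true number: the limit of > 10000 nM in this assay, at which 1 of the 4 values shown sits. Even so, the steps to it are large: an at least 520-fold higher number from compound 3 to compound 4 (2.72 log units; beyond the scatter), an at least 2200-fold higher number from compound 2 to compound 4 (3.34 log units; beyond the scatter) and an at least 37-fold higher number from compound 1 to compound 4 (1.56 log units; beyond the scatter). The earlier compounds shown here showed that hydrogen, methoxy and trifluoromethyl on this aromatic carbon all give readable numbers, whereas phenyl, with its second aromatic ring, gives none within the assay's range.

On these data alone, how far beyond the limit compound 4 lies remains open. So does how an amine, a carboxylic acid or a longer chain would read at this place.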